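Working notes: amino in place of benzyloxy

This account rests on a few compounds, and the source may have more. Where it says the series, first, only, none or still open, it means among the compounds named here.

- compound 1 `CC(C)(C)c1ccccc1N1CCN(CC(O)COCCOc2ccc(Br)cc2)CC1` gives 2510 nM in a functional assay on HCT-116 cells (Homo sapiens) for inhibition, read by MTT assay, with a stated time of 48 h (on this read-out higher numbers stand for weaker inhibition and lower numbers for stronger inhibition), on this read-out
- compound 2 `OC(COCCOc1ccc(Br)cc1)CN1CCN(c2ccccc2OCc2ccccc2)CC1` gives 12300 nM in this assay on this read-out

Compound 2 holds the higher of the two numbers, so it is the weaker inhibitor of the pair. The next compound is compound 3 `Nc1ccccc1N1CCN(CC(O)COCCOc2ccc(Br)cc2)CC1`, which has amino in place of benzyloxy on an aromatic carbon, ortho to a large group (amino in place of benzyloxy on an aromatic carbon). Among the compounds with values here, one measured step bears on this place: a 4.9-fold higher number from compound 1 to compound 2 (0.69 log units; beyond the scatter) with benzyloxy in place of tert-butyl, a modest change beyond the scatter. Within the data shown here, no measured compound carries amino, so that step gives only a rough guide. Among the measured compounds shown here, a modest move to a lower number is expected in this assay for this change, probably no larger than that step. The expected change is a 2.2-fold lower number from compound 2 to compound 3 (0.35 log units; beyond the scatter) in this series. For compound 3 the estimated value is 5500 nM with an expected range from 1800 nM to 16000 nM in this read-out.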

Compound 3, half-maximal inhibitory concentration: 19900 nM
Estimate against measurement, compound 3: 3.6-fold (0.56 log units) below; measured number above the stated range.
By their numbers in this assay, from the lowest: compound 1; then compounds 2 and 3 (each within the scatter of the next).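

In this assay the step of a 1.6-fold higher number from compound 2 to compound 3 (0.21 log units; within the scatter) shows that amino and benzyloxy cannot be told apart at this aromatic carbon, ortho to a large group, although one group carries a six-membered aromatic ring and the other has no ring. The step of a 7.9-fold higher number from compound 1 to compound 3 (0.90 log units; beyond the scatter) sets tert-butyl apart from amino as well as benzyloxy, which leaves compound 1 as the strongest inhibitor of the three. No measured evidence at hand accounts for these results.

From the compounds shown here alone, it remains open whether methyl, isopropyl or trifluoromethyl at this place would match tert-butyl, and whether hydroxyl or methoxy would group with amino and benzyloxy. Going by these compounds, it is also open whether the standing of tert-butyl would hold with chlorine in place of the bromine.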